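Fused-ring series: methylsulfanyl replaces chloro, growth inhibition expected

The source may hold more compounds than are shown below. What is called first, only, known or untested is meant among the compounds shown, and "the series" means these compounds.

Measured so far:
compound 1 `COc1cc(C)nc2n/c(=N/C(=O)c3c(-c4ccc(Cl)cc4Cl)noc3C)sn12` — 26.4%
compound 2 `COc1cc(OC)n2s/c(=N\C(=O)c3c(-c4ccc(Cl)cc4Cl)noc3C)nc2n1` — 49.3%
compound 3 `COc1cc(Cl)nc2n/c(=N/C(=O)c3c(-c4ccc(Cl)cc4Cl)noc3C)sn12` — 28.6%

In a functional assay on the whole organism for inhibition, with Brassica napus as the target, with a stated time of 72 h, tested at 10 mg/L (on this read-out lower numbers stand for less inhibition of growth and higher numbers for more inhibition of growth at the one concentration tested), compound 3 stands second highest of the three numbers. Its nearest neighbour is compound 1, with a number 2.2 percentage points higher from compound 1 to compound 3 (within the scatter) separating them, so the two are indistinguishable here. The only separation beyond the scatter is a number 20.7 percentage points lower from compound 2 to compound 3 (beyond the scatter), a modest one. The other step, a number 22.9 percentage points higher from compound 1 to compound 2 (beyond the scatter), is likewise modest and beyond the scatter.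

The next compound, compound 4 `COc1cc(SC)nc2n/c(=N/C(=O)c3c(-c4ccc(Cl)cc4Cl)noc3C)sn12`, has not been measured. Its change from compound 3 is methylsulfanyl in place of chloro on an aromatic carbon; the leaving chloro is one heavy atom, the entering methylsulfanyl is two heavy atoms with one hydrogen-bond acceptor.

Going by the values given here, two measured steps bear on this site: the exchange of methyl for chloro, a number 2.2 percentage points higher from compound 1 to compound 3 (within the scatter), and the exchange of methoxy for chloro, a number 20.7 percentage points lower from compound 2 to compound 3 (beyond the scatter). A methyl at this carbon gave no change beyond the scatter, while a two-heavy-atom group with an acceptor gave a modest rise. The entering methylsulfanyl shares that count with methoxy, so a modest rise in this assay is expected, though less certain than the methoxy case.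

The estimate for compound 4 is 38%, range 20% to 58%. The step this implies, a number 9.4 percentage points higher from compound 3 to compound 4 (within the scatter), is expected to be modest and upward.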

Compound 4, percent growth inhibition at one concentration: 27.4%
Estimate against measurement, compound 4: 10.6 percentage points above, and the stated range covers the measured number.
By their numbers in this assay, from the lowest: compounds 1, 4 and 3 (each within the scatter of the next); then compound 2.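

In this assay, the methylsulfanyl group on this aromatic carbon, next to the ring nitrogen, does not separate from chloro, with a number 1.2 percentage points lower from compound 3 to compound 4 (within the scatter), or from methyl, with a number 1 percentage points higher from compound 1 to compound 4 (within the scatter). Among the four groups compared at this carbon, methoxy alone stands apart, and the step to methylsulfanyl is a number 21.9 percentage points lower from compound 2 to compound 4 (beyond the scatter), so the two-heavy-atom count shared by methoxy and methylsulfanyl does not by itself bring compound 4 to the level of compound 2; this series therefore points to something particular to methoxy rather than to group size as counted here. Nothing available explains why methoxy and methylsulfanyl differ at this carbon.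

Still open, as far as these compounds go, is whether a longer alkoxy chain such as ethoxy, or an amine such as dimethylamino, on this carbon would fall with methoxy or with the group of methyl, chloro and methylsulfanyl. From the compounds shown here alone, with only one concentration in this assay, it also remains open whether the gap between compound 2 and compound 4 would persist across a range of concentrations.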